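This account rests on a few compounds, and the source may have more. Where it says the series, first, only, none or still open, it means among the compounds named here.

The measured compounds:
compound 1, `COc1cc2ncnc(Nc3ccc(F)c(Br)c3)c2cc1OCCCN1CCNCCNCCNCC1`, with 11800 nM;
compound 2, `COc1cc2ncnc(Nc3ccc(Cl)c(C(F)(F)F)c3)c2cc1OCCCN1CCNCCNCCNCC1`, with 5350 nM;
compound 3, `COc1cc2ncnc(Nc3ccc(F)c(Br)c3)c2cc1OCCCN1CCNCCNCC1`, with 34300 nM.

All three were tested in a functional assay on A549 cells (Homo sapiens) for antiproliferative activity, read by MTT assay, with a stated time of 72 h; on this read-out lower numbers stand for stronger inhibition and higher numbers for weaker inhibition. Compound 2 differs from compound 1 in one place, (4-chloro-3-(trifluoromethyl)phenyl in place of 3-bromo-4-fluorophenyl on a nitrogen on an aromatic ring), and this change gave a 2.2-fold lower number from compound 1 to compound 2 (0.34 log units; beyond the scatter). Compound 3 differs from compound 1 in its core, (a group of 9 heavy atoms (6 carbon, 3 nitrogen; one nine-membered non-aromatic ring with 3 hetero atoms) in place of a group of 12 heavy atoms (8 carbon, 4 nitrogen; one twelve-membered non-aromatic ring with 4 hetero atoms), on a saturated chain carbon, three bonds along the chain from an oxygen on an aromatic ring), and this gave a 2.9-fold higher number from compound 1 to compound 3 (0.46 log units; beyond the scatter), leaving compound 3 with the highest number of the three. Compound 4, `COc1cc2ncnc(Nc3ccc(Cl)c(C(F)(F)F)c3)c2cc1OCCCN1CCNCCNCC1`, has not yet been measured; it stands to compound 3 as compound 2 stands to compound 1, namely (4-chloro-3-(trifluoromethyl)phenyl in place of 3-bromo-4-fluorophenyl on a nitrogen on an aromatic ring). The place of the change is the same, word for word, in both pairs, so it is the same change carried onto the core of compound 3. Because the earlier instance gave a 2.2-fold lower number from compound 1 to compound 2 (0.34 log units; beyond the scatter), a step of similar size is expected here, a 2.2-fold lower number from compound 3 to compound 4 (0.34 log units; beyond the scatter), though this expectation rests on a single pair and the cores differ. Compound 4 is therefore estimated at 15600 nM, expected to fall between 7000 nM and 35000 nM.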

Compound 4, half-maximal inhibitory concentration: 6230 nM
Estimate against measurement, compound 4: 2.5-fold (0.40 log units) above; measured number below the stated range.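

In this assay, placing 4-chloro-3-(trifluoromethyl)phenyl on the core of compound 3 gave a 5.5-fold lower number from compound 3 to compound 4 (0.74 log units; beyond the scatter), in the same direction as on the core of compound 1, and the two steps cannot be told apart: the same change on two cores in this assay, a 2.2-fold lower number (0.34 log units; beyond the scatter) from compound 1 to compound 2 and a 5.5-fold lower number (0.74 log units; beyond the scatter) from compound 3 to compound 4, 2.5-fold (0.40 log units) apart, within the scatter of two such steps

Read the other way, the nine-membered ring in place of the larger ring gave a 1.2-fold higher number from compound 2 to compound 4 (0.07 log units; within the scatter), so with 4-chloro-3-(trifluoromethyl)phenyl present the two rings stand within the scatter of each other, yet this step also cannot be told apart from its counterpart with 3-bromo-4-fluorophenyl: the same change on two cores in this assay, a 2.9-fold higher number (0.46 log units; beyond the scatter) from compound 1 to compound 3 and a 1.2-fold higher number (0.07 log units; within the scatter) from compound 2 to compound 4, 2.5-fold (0.40 log units) apart, within the scatter of two such steps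

The change therefore carried over in direction on these two cores, but two pairs fix no exact size for it and show nothing about any other core.

The compounds shown leave open whether a plain phenyl group on the nitrogen would follow the same course. They also leave open how the change would behave with an open-chain amine in place of the ring, or with a longer chain leading to it.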